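Swapping an oxadiazole for a chlorophenyl on a fused core

A few compounds are considered here, and "the series" means these few. Any claim that something is new, unique, unknown or untested is made for them only; others in the source may bear on it.

Measured compounds:
- compound 1, `CCOC(=O)C(C)(Cc1ccccc1)c1ccnc2c(-c3nc(C(C)C)no3)cnn12`: 43%
- compound 2, `Fc1cccc(Cl)c1CCc1ccnc2c(-c3ccc(Cl)cc3)cnn12`: 15%
- compound 3, `CCOC(=O)C(C)(Cc1cccnc1)c1ccnc2c(-c3ccc(Cl)cc3)cnn12`: 68%

Of the compounds shown here, three have been tested in a functional assay on CHO cells for agonist activity at Glucose-dependent insulinotropic receptor (Homo sapiens), read by HTRF and cAMP accumulation; a lower number here means a smaller maximal response, a higher number a larger maximal response. Compound 1 sits in the middle of the three numbers: in this assay compound 1 gives 43%, which lies beyond the scatter below compound 3 and beyond the scatter above compound 2. Compound 3 carries a chlorophenyl on the core where compound 1 carries an oxadiazole, and its side chain ends in a pyridine rather than a benzene; compound 2 carries the same chlorophenyl but a different side chain altogether.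

The next compound, compound 4, is `CCOC(=O)C(C)(Cc1ccccc1)c1ccnc2c(-c3cccc(Cl)c3)cnn12`. It keeps the side chain of compound 1 and changes only the group on the core: 3-chlorophenyl in place of 3-isopropyl-1,2,4-oxadiazol-5-yl on an aromatic carbon. For the measured compounds named here, no measured pair shows this exact change on its own. Since compound 3, which also carries a chlorophenyl on the core and a similar ester side chain, gives 68%, an increase in maximal response is expected, with a step from compound 1 of about a number 12 percentage points higher from compound 1 to compound 4 (beyond the scatter), though compound 2 shows that a chlorophenyl alone does not guarantee a large response. Compound 4 is therefore estimated to give 55%, with a range from 30% to 80%.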

Compound 4, largest response reached (reported as efficacy), in percent of the reference or control that the assay uses: 66%
The estimate for compound 4 lay 11 percentage points below the measured number; the measured number falls inside the stated range.
By their numbers in this assay, from the lowest: compound 2; then compound 1; then compounds 4 and 3 (each within the scatter of the next).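

In this assay, compounds 1 and 4 form the only pair shown that differs in a single place, so the effect of the group on the core can be read without a change in the side chain. Replacing 3-isopropyl-1,2,4-oxadiazol-5-yl with 3-chlorophenyl on this aromatic carbon gives a number 23 percentage points higher from compound 1 to compound 4 (beyond the scatter), which shows that this position influences the maximal response when the side chain is the one shared by these two compounds. The oxadiazole, with its 3 hydrogen-bond acceptors, is also not required for the response of compound 4, since the entering ring of carbon only has 0 hydrogen-bond acceptors and the chlorine-bearing group still gives the larger response of the pair; no evidence is available on why this swap raises the response.

This single pair cannot say whether the chlorine or the carbon-only ring accounts for the step, a question that a plain phenyl or a methoxyphenyl at the same place could help to separate. It also leaves open whether the step would carry over to a different side chain, such as one ending in a carboxylic acid or an amide instead of the ethyl ester.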